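This account rests on a few compounds, and the source may have more. Where it says the series, first, only, none or still open, it means among the compounds named here.

Compound 1, `CCCCCCCCCC(CCO)n1cnc2c(OC)ncnc21`: 2530 nM
Compound 2, `CCCCCCCCCC(CCO)n1cnc2c(N)ncnc21`: 10500 nM

Of the compounds shown here, two have been measured in a functional assay on HCT-116 cells (Homo sapiens) for antiproliferative activity, read by MTT assay, with a stated time of 48 h; a higher number here means a weaker inhibitor, a lower number a stronger inhibitor. Compound 1 gives 2530 nM and compound 2 gives 10500 nM; the step between them, a 4.2-fold higher number from compound 1 to compound 2 (0.62 log units; beyond the scatter), arises from amino in place of methoxy on an aromatic carbon. Compound 2 therefore stands at the higher of the two numbers, the weaker inhibitor of the pair. Compound 3 is `CCCCCCCCCCCC(CCO)n1cnc2c(N)ncnc21`. It keeps the amino group of compound 2 and differs only in the chain: ethyl in place of hydrogen on a saturated chain carbon, ten or more bonds along the chain from an aromatic nitrogen. Going by the values given here, no measured step alters the chain, so the one step in hand, a 4.2-fold higher number from compound 1 to compound 2 (0.62 log units; beyond the scatter), concerns another part of the molecule and says little about what a longer chain will do. With nothing to set a direction, a step in this assay no larger than the scatter is expected, a 1.3-fold lower number from compound 2 to compound 3 (0.12 log units; within the scatter). Compound 3 is accordingly estimated at 8000 nM, within a range from 3000 nM to 25000 nM.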

Compound 3, half-maximal inhibitory concentration: 13400 nM
Compound 3: the middle estimate sits 1.7-fold (0.22 log units) below what was measured, and the stated range covers the measured number.
By their numbers in this assay, from the lowest: compound 1; then compounds 2 and 3 (each within the scatter of the next).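

Ethyl in place of hydrogen, on a saturated chain carbon, gives a 1.3-fold higher number from compound 2 to compound 3 (0.11 log units; within the scatter) in this assay, so the numbers for this pair cannot be told apart. Going by these compounds alone, this is the first measured look at the chain, and at this position the added ethyl leaves no effect that can be separated from the scatter, whereas amino in place of methoxy on an aromatic carbon gave a 4.2-fold higher number from compound 1 to compound 2 (0.62 log units; beyond the scatter). Nothing available here explains why this chain change shows so little.

Going by these compounds, whether methoxy in place of amino would give a similar step with the chain of compound 3 remains open. Also open, on these data alone, is what a much longer chain, a much shorter chain, or an amine or a carboxylic acid in place of the ethyl would do.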